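The source may hold more compounds than are shown below. What is called first, only, known or untested is meant among the compounds shown, and "the series" means these compounds.

Compound 1, `Cc1ccccc1NC(=S)N/N=C/c1ccc(O)cc1`, gives 36500 nM in an assay for inhibition of ribonucleoside-diphosphate reductase RR1 (Homo sapiens), with a stated time of 30 min; on this read-out lower numbers stand for stronger inhibition and higher numbers for weaker inhibition.
Compound 2, `Cc1cccc(NC(=S)N/N=C/c2ccc(O)cc2)c1`, gives 30400 nM in this assay.
Compound 3, `Oc1ccc(/C=N/NC(=S)Nc2ccccc2O)cc1`, gives 29300 nM in this assay.

All three measured compounds share the same thiosemicarbazone backbone, and all three numbers lie within the scatter of one another, so none can be called stronger or weaker. Compound 4, `Oc1ccc(/C=N/NC(=S)Nc2cccc(O)c2)cc1`, has not yet been measured in this assay.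

The change from compound 1 to compound 3 is hydroxy in place of methyl on an aromatic carbon, and it made a step of a 1.2-fold lower number from compound 1 to compound 3 (0.10 log units; within the scatter). The change from compound 2 to compound 4 is hydroxy in place of methyl on an aromatic carbon. This is the same kind of change, but not the same: in compound 1 the place is ortho to a large group, in compound 2 it is meta to a large group. The difference between the core of compound 1 and the core of compound 2 is not broken down here.

Because the step of a 1.2-fold lower number from compound 1 to compound 3 (0.10 log units; within the scatter) was small, the expected step from compound 2 to compound 4 is also small, a 1.2-fold lower number from compound 2 to compound 4 (0.07 log units; within the scatter). Compound 4 is therefore estimated at 26000 nM, with a range from 12000 nM to 55000 nM.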

Compound 4, half-maximal inhibitory concentration: 28600 nM
Compound 4: the middle estimate sits 1.1-fold (0.04 log units) below what was measured, within the range that was stated.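

In this assay, hydroxy in place of methyl on an aromatic carbon gives a 1.1-fold lower number from compound 2 to compound 4 (0.03 log units; within the scatter), so the numbers for this pair cannot be told apart. Set beside the earlier step, the same swap gives a matching result on the two cores: the same change on two cores in this assay, a 1.2-fold lower number (0.10 log units; within the scatter) from compound 1 to compound 3 and a 1.1-fold lower number (0.03 log units; within the scatter) from compound 2 to compound 4, 1.2-fold (0.07 log units) apart, within the scatter of two such steps. This shows that in these two pairs the swap can be made on either core without a step beyond the scatter, but it does not show that an effect carries from one core to another, since neither step is large enough to be told from repeat-to-repeat noise.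

The compounds shown carry only methyl or hydroxy on this ring, so it remains open what an amine, a carboxylic acid or a longer chain would do there. Also open, going by these compounds, is whether the shared hydroxy on the other ring matters, and whether any change on either ring could give a number clearly apart from these.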